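Swapping the aryl group on a sulfonamide

This account rests on a few compounds, and the source may have more. Where it says the series, first, only, none or still open, it means among the compounds named here.

Measured so far:
compound 1 `CN(C(=O)c1ccco1)c1ccc2[nH]c(-c3n[nH]c4ccccc34)cc2n1` — 15500 nM
compound 2 `CN(c1ccc2[nH]c(-c3n[nH]c4ccccc34)cc2n1)S(=O)(=O)c1ccc(Cl)cc1` — 18200 nM

In a functional assay on A549 cells (Homo sapiens) for antiproliferative activity, read by MTT assay, with a stated time of 72 h (on this read-out lower numbers stand for stronger inhibition and higher numbers for weaker inhibition), compound 2 holds the highest of the two numbers; its nearest neighbour is compound 1, and the step of a 1.2-fold higher number from compound 1 to compound 2 (0.07 log units; within the scatter) lies within the scatter. Compound 3 `CN(c1ccc2[nH]c(-c3n[nH]c4ccccc34)cc2n1)S(=O)(=O)c1cccc([N+](=O)[O-])c1` differs from compound 2 by 3-nitrophenyl in place of 4-chlorophenyl on a sulfonyl sulfur. No measured step changes the group on the sulfonyl sulfur, so nothing shown bears directly on this change; the one step known, a 1.2-fold higher number from compound 1 to compound 2 (0.07 log units; within the scatter), is a different change and small. The expectation is therefore no step beyond the scatter, a 1.0-fold lower number from compound 2 to compound 3 (0.00 log units; within the scatter). Compound 3 is estimated at 18000 nM, ranging from 7000 nM to 45000 nM.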

Compound 3, half-maximal inhibitory concentration: 20100 nM
Compound 3: middle estimate off by 1.1-fold (0.05 log units), on the low side, within the range that was stated.
By their numbers in this assay, from the lowest: compounds 1, 2 and 3 (each within the scatter of the next).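

In this assay, the step for 3-nitrophenyl in place of 4-chlorophenyl on the sulfonyl sulfur is a 1.1-fold higher number from compound 2 to compound 3 (0.04 log units; within the scatter) and shows that these two aryl groups cannot be told apart here. This holds even though 3-nitrophenyl has more heavy atoms and carries hydrogen-bond acceptors, while 4-chlorophenyl carries none. Nothing available explains this result. Still open, on these data alone, is whether an amine or a carboxylic acid on the phenyl ring, or a methyl in place of the whole aryl group, would move the number beyond the scatter.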